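This account rests on a few compounds, and the source may have more. Where it says the series, first, only, none or still open, it means among the compounds named here.

Compound 1 `O=C1N=C(N2CCC[C@H]2C(=O)Nc2ccc3ncnc(Nc4cccc(Cl)c4)c3c2)S/C1=C/c1cccnc1` carries pyridin-3-yl on a double-bonded chain carbon bound to a double-bonded ring carbon. In a functional assay on A549 cells (Homo sapiens) for antiproliferative activity, read by MTT assay (on this read-out higher numbers stand for weaker inhibition and lower numbers for stronger inhibition), compound 1 gives 10400 nM. Compound 2 `COc1ccccc1/C=C1/SC(N2CCC[C@H]2C(=O)Nc2ccc3ncnc(Nc4cccc(Cl)c4)c3c2)=NC1=O` carries 2-methoxyphenyl at that place. In this assay compound 2 gives only a limit, > 50000 nM. Compound 3 `O=C1N=C(N2CCC[C@H]2C(=O)Nc2ccc3ncnc(Nc4cccc(Cl)c4)c3c2)S/C1=C/c1ccc2ccccc2n1`, with quinolin-2-yl there, also gives only a limit, > 50000 nM. Compound 2 therefore stands at the weak end of what has been measured, because of the limit of > 50000 nM in this assay, at which 2 of the 3 values shown sit. Compound 4 `Cc1cccc(/C=C2/SC(N3CCC[C@H]3C(=O)Nc3ccc4ncnc(Nc5cccc(Cl)c5)c4c3)=NC2=O)n1` differs from compound 2 by 6-methylpyridin-2-yl in place of 2-methoxyphenyl on a double-bonded chain carbon bound to a double-bonded ring carbon. The steps bearing on it are an at least 4.8-fold higher number from compound 1 to compound 2 (0.68 log units; beyond the scatter) and a step that the two limits leave unreadable from compound 2 to compound 3. Compound 4 resembles compound 1 in carrying a pyridine, yet compound 3 stayed at the limit, so for compound 4 a value near the limit is expected, estimated at 30000 nM within 8000 nM to 50000 nM. That expectation means a step of an at least 1.6-fold lower number from compound 2 to compound 4 (0.22 log units; that floor lies within the scatter).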

Compound 4, half-maximal inhibitory concentration: 8500 nM
Estimate against measurement, compound 4: 3.5-fold (0.55 log units) above, within the range that was stated.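

In this assay, 6-methylpyridin-2-yl improves on both earlier groups at this place, with an at least 5.8-fold lower number from compound 2 to compound 4 (0.76 log units; beyond the scatter) and an at least 5.8-fold lower number from compound 3 to compound 4 (0.76 log units; beyond the scatter). Against pyridin-3-yl there is a 1.2-fold lower number from compound 1 to compound 4 (0.09 log units; within the scatter), so these two pyridines read alike, while quinolin-2-yl, which also holds a ring nitrogen, goes against any rule that such a nitrogen is enough. Compound 2 and compound 3 remain limits, not numbers: the limit of > 50000 nM in this assay, at which 2 of the 4 values shown sit.

From the compounds shown here alone, the ring nitrogen and the methyl enter together, so their shares stay open. A plain pyridin-2-yl group would separate them.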